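Replacing methylseleno with amino on a fused pyridopyrimidine core

The compounds below may be only part of what the source reports. "The series", "measured", "known", "first", "only" and "open" are said of these compounds alone.

Measured compounds in a functional assay on MCF7 cells (Homo sapiens) for cytotoxicity, read by MTT assay, with a stated time of 72 h; a higher number here means that more compound is tolerated, a lower number that less compound is tolerated:
compound 1, `Nc1nc([SeH])nc2ncccc12`: > 100000 nM
compound 2, `C[Se]c1nc([Se]C)c2cccnc2n1`: "not determined" (no result reported)
compound 3, `[SeH]c1nc([SeH])c2cccnc2n1`: 82700 nM

The value of compound 1 is a limit of the assay, not a number (the limit of > 100000 nM in this assay, at which 1 of the 3 values shown sits). Compound 2 has no result of its own in this assay, so it cannot be placed among the others. Compound 4, `C[Se]c1nc(N)c2cccnc2n1`, differs from compound 2 in one place: one nitrogen atom in place of a group of 2 heavy atoms (1 carbon, 1 selenium; no ring), on an aromatic carbon. For the measured compounds named here, no measured step matches this change. Going by the values given here, the only measured step, an at least 1.2-fold lower number from compound 1 to compound 3 (0.08 log units; that floor lies within the scatter), swaps a different group and lies within the scatter. Compounds 1 and 3 both tolerate very high concentrations, so compound 4 is expected to behave similarly, with an estimate of 100000 nM, ranging from 40000 nM to 250000 nM.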

Compound 4, concentration lethal to 50% of the cells: > 100000 nM
Compound 4 ended at the assay's limit; the forecaster's own chance of this, stated with the estimate: 50%; the middle value sits exactly at the limit.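

Compound 1 and compound 4 both end at a limit of the assay rather than a number, so no step between them can be read: the limit of > 100000 nM in this assay, at which 2 of the 4 values shown sit.

The compounds shown leave open whether methyl in place of hydrogen on a selenium changes the tolerated concentration at all.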